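The source may hold more compounds than are shown below. What is called first, only, known or untested is meant among the compounds shown, and "the series" means these compounds.

Among the measured compounds shown here, the two compounds measured so far share one core and differ only in the side chain attached to it. Compound 1, `O=C(NCc1ccccc1Br)N1C(=O)c2ccccc2S1(=O)=O`, was tested in a physicochemical assay for pharmacokinetics; on this read-out higher numbers stand for a longer-lived compound and lower numbers for a shorter-lived compound. In this assay compound 1 gives > 166 h, which is a limit of the assay rather than a number. Compound 2, `O=C(CCc1ccccc1)N1C(=O)c2ccccc2S1(=O)=O`, in this assay gives > 166 h, again a limit. Both values sit at the limit of > 166 h in this assay, at which 2 of the 2 values shown sit, so compound 1 stands where every measured value stands, and nothing here separates the two compounds. Compound 3, `O=C(NCc1ccccc1F)N1C(=O)c2ccccc2S1(=O)=O`, is not yet measured; it differs from compound 1 by fluoro in place of bromo on an aromatic carbon. For the measured compounds named here, no measured pair shows what such a swap does here. Because compound 1 sits at the limit of > 166 h in this assay, at which 2 of the 2 values shown sit, the expected step that the limit leaves unreadable from compound 1 to compound 3 is none beyond the scatter. Compound 3 is therefore expected to give about 250 h in this assay, between 120 h and 500 h, and most likely once more only a limit.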

Compound 3, half-life: > 166 h
Compound 3: a limit, no number; the forecaster's own chance of this, stated with the estimate: 75%; the middle value is on the limit's open side.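

Among the compounds shown here, no step from compound 1 to compound 3 can be read, since both results in this assay are limits and not numbers: the limit of > 166 h in this assay, at which 3 of the 3 values shown sit. The compounds shown leave open what the actual half-lives are, and whether fluoro in place of bromo on an aromatic carbon changes them at all.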